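Ester to Pyrrolidine Amide: One Change, One Expectation

The source may hold more compounds than are shown below. What is called first, only, known or untested is meant among the compounds shown, and "the series" means these compounds.

Three compounds were examined in a functional assay on L1210 cells (Mus musculus) for antiproliferative activity; a lower number here means a less potent compound, a higher number a more potent compound, by a factor of ten per unit of this negative logarithm. Compound 1 `COC(=O)c1n[nH]c(C(C)C)c1/N=N/N(C)C` gives 3.3, compound 2 `CCOC(=O)c1ccc(/N=N/N(C)CC(C)C)cc1` gives 2.8, and compound 3 `CN/N=N/c1nc[nH]c1C(=O)OC` gives 3.35. The number for compound 3 is the highest of the three, yet compound 1 sits within the usual scatter of it, so those two cannot be ordered; only compound 2 lies beyond the scatter, lower than compound 3. Compound 4 `CN/N=N/c1nc[nH]c1C(=O)N1CCCC1` has not yet been measured. It differs from compound 3 in one place: pyrrolidin-1-yl in place of methoxy on a carbonyl carbon. Among the measured compounds shown here, no step between measured compounds exists to guide this change. Compound 4 is expected to give about 3.2, with a range from 2.6 to 3.8. The estimated step is a number 0.15 log units lower from compound 3 to compound 4 (within the scatter), expected to fall within the scatter, in no clear direction.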

Compound 4, logarithm of the reciprocal of the active concentration, log(1/C): 3.28
Beside the measured number, compound 4's estimate is 0.08 log units below it; low and high end bracket the measured number.
By their numbers in this assay, from the lowest: compound 2; then compounds 4, 1 and 3 (each within the scatter of the next).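

In this assay the exchange of methoxy for pyrrolidin-1-yl on this carbonyl carbon gives the first step measured at this position, a number 0.07 log units lower from compound 3 to compound 4 (within the scatter) and so the larger group with its five-membered non-aromatic ring is tolerated here. For this pair, then, the ester is not required for the antiproliferative read-out. Nothing shown gives a reason for this result.

On these data alone, whether a carboxylic acid or a primary amide on this carbonyl carbon would also stay within the scatter of compound 3 remains open. So does whether the same exchange holds on the core of compound 1.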